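Methyl added to the triazole-linked phenyl of compound 2

This account rests on a few compounds, and the source may have more. Where it says the series, first, only, none or still open, it means among the compounds named here.

Measured compounds:
compound 1 `O=c1[nH]cc(S(=O)(=O)Nc2ccccc2-c2cn(-c3ccccc3Cl)nn2)c(=O)[nH]1` — 22800 nM
compound 2 `O=c1[nH]cc(S(=O)(=O)Nc2ccc(-c3cn(-c4ccccc4)nn3)cc2)c(=O)[nH]1` — "not toxic" (no number reported)

Two compounds of the series have been examined in an ADME assay on L02 cells (Homo sapiens) for cytotoxicity, read by MTT assay, with a stated time of 24 h; a higher number here means that more compound is tolerated, a lower number that less compound is tolerated. Compound 1 `O=c1[nH]cc(S(=O)(=O)Nc2ccccc2-c2cn(-c3ccccc3Cl)nn2)c(=O)[nH]1` gives 22800 nM. For compound 2 `O=c1[nH]cc(S(=O)(=O)Nc2ccc(-c3cn(-c4ccccc4)nn3)cc2)c(=O)[nH]1` the result reads "not toxic" (no number reported), so no number stands for it and its position on the scale can only be described as tolerated at the concentrations tested. For the measured compounds named here, compound 1 and compound 2 differ at more than one place, so no single step connects them, and what the two results show is simply that both are tolerated at high concentration.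

Compound 3 `Cc1ccc(-n2cc(-c3ccc(NS(=O)(=O)c4c[nH]c(=O)[nH]c4=O)cc3)nn2)cc1` is the next member to be measured in this assay. It differs from compound 2 by methyl in place of hydrogen on an aromatic carbon. Going by the values given here, no step between measured compounds covers this change; the expectation for this assay is a step that stays within the scatter, with no direction beyond it. Compound 3 is therefore expected at 40000 nM in this assay, with the estimate spanning 15000 nM to 120000 nM, and a fair chance that again only a tolerated outcome without a number is reported.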

Compound 3, half-maximal cytotoxic concentration: "not toxic" (no number reported)
No number was reported for compound 3; there is nothing to compare the estimate with.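

In this assay compound 2 gives "not toxic" (no number reported) and compound 3 gives "not toxic" (no number reported) with no number on either side, so no step can be read for phenyl to 4-methylphenyl. The compounds shown leave open whether methyl in place of hydrogen shifts tolerance at all. No evidence bears on this result.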